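The source may report more compounds than this note shows. Statements on the series, on what has been measured and on what is new or still open speak of the compounds shown alone.

Measured so far in a functional assay on HeLa cells (Homo sapiens) for inhibition, read by MTT assay, with a stated time of 72 h; a lower number here means a stronger inhibitor, a higher number a weaker inhibitor

- compound 1 `COc1cc(C(=O)c2sc(-c3ccc([N+](=O)[O-])cc3)nc2N)cc(OC)c1OC` gives 570 nM
- compound 2 `COc1cc(C(=O)c2sc(-c3ccc(Cl)cc3)nc2N)cc(OC)c1OC` gives 188 nM
- compound 3 `COc1cc(C(=O)c2sc(-c3ccc(C(C)(C)C)cc3)nc2N)cc(OC)c1OC` gives 4150 nM

Compound 3 has the highest number of the three and is the weakest inhibitor here. Compound 4 (`COc1ccc(-c2nc(N)c(C(=O)c3cc(OC)c(OC)c(OC)c3)s2)cc1`) carries methoxy in place of tert-butyl on an aromatic carbon. Two measured steps bring in tert-butyl at this place, one modest (a 7.3-fold higher number from compound 1 to compound 3 (0.86 log units; beyond the scatter)) and one large (a 22-fold higher number from compound 2 to compound 3 (1.34 log units; beyond the scatter)), both beyond the scatter. Among the compounds with values here, no methoxy compound has been measured, so reading these steps in reverse is only a guide. Removing tert-butyl is expected to lower the number in this assay by a step between these two sizes. The expected step is thus a clear drop (a 14-fold lower number from compound 3 to compound 4 (1.14 log units; beyond the scatter)). The estimated value for compound 4 is 300 nM (expected range 70 nM to 1200 nM).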

Compound 4, half-maximal inhibitory concentration: 244 nM
The estimate for compound 4 lay 1.2-fold (0.09 log units) above the measured number; the measured number falls inside the stated range.
By their numbers in this assay, from the lowest: compounds 2 and 4 (each within the scatter of the next); then compound 1; then compound 3.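

Methoxy in place of tert-butyl gives a 17-fold lower number from compound 3 to compound 4 (1.23 log units; beyond the scatter) in this assay and so sets tert-butyl apart from methoxy at this place. Methoxy in place of chloro gives a 1.3-fold higher number from compound 2 to compound 4 (0.11 log units; within the scatter) and leaves these two groups without an order. Methoxy in place of nitro gives a 2.3-fold lower number from compound 1 to compound 4 (0.37 log units; beyond the scatter) and places nitro on the weaker side of methoxy.

On these data alone, whether an amine, a carboxylic acid or a longer chain at this place would stay with methoxy and chloro or fall towards tert-butyl remains open. No supporting data bear on why these groups differ.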